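Diethylamino gives way to acetamido on compound 2

This account rests on a few compounds, and the source may have more. Where it says the series, first, only, none or still open, it means among the compounds named here.

Of the compounds shown here, two that share one core have so far been measured in an in vitro assay on CHO cells for binding affinity to Substance-P receptor (Homo sapiens); on this read-out lower numbers stand for stronger inhibition and higher numbers for weaker inhibition. Compound 1 `COc1ccc(-n2nnnc2S(C)(=O)=O)cc1CN[C@H]1CCCN[C@H]1c1ccccc1` gives 0.0631 nM. Within the data shown here, compound 2 `CCN(CC)c1nnnn1-c1ccc(OC)c(CN[C@H]2CCCN[C@H]2c2ccccc2)c1` gives 2 nM, the higher of the two numbers, and the single measured step, a 32-fold higher number from compound 1 to compound 2 (1.50 log units; beyond the scatter), came with diethylamino in place of methylsulfonyl on an aromatic carbon. Compound 3 `COc1ccc(-n2nnnc2NC(C)=O)cc1CN[C@H]1CCCN[C@H]1c1ccccc1` differs from compound 2 in one place: acetamido in place of diethylamino on an aromatic carbon. Among the measured compounds shown here, no measured compound carries acetamido, so only that one step bears on the change. Because the large step of a 32-fold higher number from compound 1 to compound 2 (1.50 log units; beyond the scatter) accompanied the arrival of diethylamino, its departure is expected to bring the number down again, though not necessarily all the way. For compound 3 the expected step is a 4.0-fold lower number from compound 2 to compound 3 (0.60 log units; beyond the scatter), a lowering beyond the scatter. Compound 3 is therefore estimated to give 0.5 nM, within a range from 0.1 nM to 3 nM.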

Compound 3, inhibition constant: 0.251 nM
Compound 3: the middle estimate sits 2.0-fold (0.30 log units) above what was measured; the measured number falls inside the stated range.
By their numbers in this assay, from the lowest: compound 1; then compound 3; then compound 2.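

With acetamido in place of diethylamino, the number falls by an 8.0-fold lower number from compound 2 to compound 3 (0.90 log units; beyond the scatter) in this assay, so a group on this aromatic carbon between two ring nitrogen atoms can restore much of the affinity lost with diethylamino without being methylsulfonyl. Acetamido does not fully match methylsulfonyl, however, and the change between them is a 4.0-fold higher number from compound 1 to compound 3 (0.60 log units; beyond the scatter) at the same position. The three groups now give three numbers separated beyond the scatter, placing acetamido between the other two, although its amide hydrogen and its smaller heavy-atom count arrive together and cannot be separated here.

From the compounds shown here alone, what a methanesulfonamido group, an unsubstituted amine or a longer acyl chain such as propanamido would give at this position remains open. Nothing available explains why the three groups rank as they do.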